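The source may hold more compounds than are shown below. What is called first, only, known or untested is meant among the compounds shown, and "the series" means these compounds.

In a functional assay on A549 cells (Homo sapiens) for cytotoxicity, read by sulforhodamine B assay (on this read-out higher numbers stand for weaker inhibition and lower numbers for stronger inhibition), compound 2 (`C=C1[C@@H](OC(C)=O)C[C@@H]2[C@](C)(COC=O)[C@H](OC(C)=O)CC[C@@]2(C)[C@@H]1C[C@@H](Nc1ccc(OC)c(OC)c1)C1=CCOC1=O`) reads > 50000 nM, which is a limit of the assay and not a number. Compound 1 (`C=C1[C@@H](OC(C)=O)C[C@@H]2[C@](C)(COC=O)[C@H](OC(C)=O)CC[C@@]2(C)[C@@H]1C[C@@H](Nc1ccc(O)cc1)C1=CCOC1=O`) gives 29100 nM. Compound 3 (`C=C1[C@@H](OC(C)=O)C[C@@H]2[C@](C)(COC=O)[C@H](OC(C)=O)CC[C@@]2(C)[C@@H]1C[C@@H](Nc1ccc(Br)cc1)C1=CCOC1=O`) carries 4-bromophenyl in place of 3,4-dimethoxyphenyl on an amine nitrogen. Going by the values given here, the one measured step bearing on this change is an at least 1.7-fold higher number from compound 1 to compound 2 (0.23 log units; that floor lies within the scatter), with 3,4-dimethoxyphenyl in place of 4-hydroxyphenyl at the same place. On that single step, a modest move towards a lower number is expected in this assay, and the expected size is an at least 1.7-fold lower number from compound 2 to compound 3 (0.25 log units; that floor lies within the scatter). Compound 3 is estimated at 28000 nM, with an expected range of 10000 nM to 50000 nM.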

Compound 3, half-maximal inhibitory concentration: 15900 nM
Compound 3: the middle estimate sits 1.8-fold (0.25 log units) above what was measured, within the range that was stated.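

In this assay, the group on the amine nitrogen now shows a change beyond the scatter: an at least 3.1-fold lower number from compound 2 to compound 3 (0.49 log units; beyond the scatter). Compound 2 stands at a limit of the assay and not at a number, so that step has only a floor: the limit of > 50000 nM in this assay, at which 1 of the 3 values shown sits. Bromo in place of hydroxy on an aromatic carbon gives a 1.8-fold lower number from compound 1 to compound 3 (0.26 log units; within the scatter), which leaves compound 1 and compound 3 within the scatter of each other.

Open, going by these compounds, is how an amine in place of bromo on that aromatic carbon would read. Also open, on these data alone, is whether a saturated longer chain on the amine nitrogen, in place of the aromatic group, would keep any of this read-out.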